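The compounds below may be only part of what the source reports. "The series", "measured", "known", "first", "only" and "open" are said of these compounds alone.

Compound 1 `COc1cc(C(=O)O)ccc1OCCCCOc1ccc(C(=O)CC(C)C)c(O)c1C` gives 2750 nM
Compound 2 `Cc1c(OCCCCOc2ccc(C(=O)O)cc2)ccc(C(=O)CC(C)C)c1O` gives 2570 nM

Among the measured compounds shown here, in an ADME assay on the whole organism for pharmacokinetics, with Rattus norvegicus as the target, at a dose of 20 mg/kg by the oral route (a higher number here means more compound in the circulation at the dose given, a lower number less compound in the circulation), compound 2 gives 2570 nM and stands level with compound 1, the only other number so far. Compound 3 `Cc1c(OCCCCOc2ccc(F)c(C(=O)O)c2)ccc(C(=O)CC(C)C)c1O` is compound 2 with one change, 3-carboxy-4-fluorophenyl in place of 4-carboxyphenyl on an oxygen on a saturated carbon. For the measured compounds named here, one measured step bears on this change, and only loosely: hydrogen in place of methoxy on an aromatic carbon gave a 1.1-fold lower number from compound 1 to compound 2 (0.03 log units; within the scatter) and so nothing beyond the scatter. Going by the values given here, no measured compound carries the 3-carboxy-4-fluorophenyl group, which leaves the evidence thin and the range wide. An expected step of a 1.1-fold lower number from compound 2 to compound 3 (0.05 log units; within the scatter) follows, with no firm direction and nothing beyond the scatter. Compound 3 is estimated at 2300 nM with an expected range from 900 nM to 5500 nM around that middle.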

Compound 3, maximal plasma concentration: 12500 nM
For compound 3 the middle estimate is 5.4-fold (0.74 log units) below the measured one, outside the stated range (above it).
By their numbers in this assay, from the lowest: compounds 2 and 1 (each within the scatter of the next); then compound 3.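

In this assay, the aryl group on the oxygen at the end of the chain matters: 3-carboxy-4-fluorophenyl in place of 4-carboxyphenyl gives a 4.9-fold higher number from compound 2 to compound 3 (0.69 log units; beyond the scatter), whereas the earlier change on the other ring, hydrogen in place of methoxy, gave only a 1.1-fold lower number from compound 1 to compound 2 (0.03 log units; within the scatter). So this is the first change shown that moves the number beyond the scatter, and compound 3 has the highest number of the three. The names show that two things differ at once, the place of the carboxy group and the added fluorine, and nothing measured here explains the rise.

Whether the fluorine, the moved carboxy group or the two together account for the step stays open. Also open, from the compounds shown here alone, is whether chlorine in place of the fluorine, or an amide in place of the carboxylic acid, would keep the higher number.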